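The source may hold more compounds than are shown below. What is called first, only, known or untested is meant among the compounds shown, and "the series" means these compounds.

Compound 3 `C=CCc1cc(C(=O)CCC)ccc1OCCCNC(C)C` stands lowest of the three numbers in an assay for inhibition of squalene synthase (Rattus norvegicus), using microsomes (a lower number here means a stronger inhibitor, a higher number a weaker inhibitor), where compound 3 gives 1 nM. Its nearest neighbour is compound 1 `CCC(=O)Nc1ccc(OCC(O)CNC(C)C)c(Cc2ccccc2)c1`, which in this assay gives 900 nM, and the furthest is compound 2 `CC(C)NCC(O)COc1ccccc1Cc1ccccc1`, which in this assay gives 8800 nM. For the measured compounds named here, the one measured step between those two, a 9.8-fold higher number from compound 1 to compound 2 (0.99 log units; beyond the scatter), shows what the loss of a group on an aromatic carbon did in that pair.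

Compound 4 `C=CCc1cc(N)ccc1OCCCNC(C)C` differs from compound 3 in one place: amino in place of propylcarbonyl on an aromatic carbon. Going by the values given here, no measured step exchanges these two groups, so the step from compound 1 to compound 2, in which a substituent on an aromatic carbon was replaced by hydrogen, is the only one that bears on the change, and it bears on it only loosely, since there the group was removed and here one group is replaced by another. On that footing a step in this assay toward a higher number, of a size comparable to that seen from compound 1 to compound 2, is expected for compound 4, with wide uncertainty: the estimated step is a 30-fold higher number from compound 3 to compound 4 (1.48 log units; beyond the scatter). Compound 4 is therefore expected to give about 30 nM in this assay, within a range from 4 nM to 300 nM.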

Compound 4, half-maximal inhibitory concentration: 250 nM
For compound 4 the middle estimate is 8.3-fold (0.92 log units) below the measured one, and the stated range covers the measured number.
By their numbers in this assay, from the lowest: compound 3; then compound 4; then compound 1; then compound 2.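

In this assay the change on the aromatic carbon para to a group of 8 heavy atoms, with amino in place of propylcarbonyl, gives a 250-fold higher number from compound 3 to compound 4 (2.40 log units; beyond the scatter) and is a large step, so on the core of compound 3 this position is sensitive to what it carries. For the compounds shown here, the only earlier step (a 9.8-fold higher number from compound 1 to compound 2 (0.99 log units; beyond the scatter)) was modest, and it showed the removal of a propanoylamino group from a different core rather than one group exchanged for another at this position. The change here takes away five heavy atoms, including the carbonyl, and brings in a single nitrogen with a hydrogen-bond donor, but nothing at hand separates these differences or explains the size of the step.

The compounds shown leave open whether the low number of compound 3 rests on the carbonyl or on the propyl chain behind it, which an acetyl group, a longer butanoyl chain or a propanoylamino group on the same carbon would help to separate. They also leave open whether a propyl group in place of the allyl group would keep that number.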